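This account rests on a few compounds, and the source may have more. Where it says the series, first, only, none or still open, it means among the compounds named here.

Series notes. Compound 1 `Nc1nc(C(F)(F)F)cc2c1[nH]c(=O)n2Cc1ccc(NCCN2CCCCC2)nc1` gives 13 mL.min-1.g-1 in an in vitro ADME assay on microsomes from liver (Homo sapiens) for pharmacokinetics; on this read-out lower numbers stand for slow clearance and higher numbers for fast clearance. Compound 2 `CN1CCN(c2ccc(Cn3c(=O)[nH]c4c(N)nc(C(F)(F)F)cc43)cn2)CC1` gives 30 mL.min-1.g-1 in this assay, and compound 3 `CN(CCN1CCCCC1)c1ccc(Cn2c(=O)[nH]c3c(N)nc(C(F)(F)F)cc32)cn1` gives 25 mL.min-1.g-1. Compound 3 thus stands second highest of the three numbers, yet its gap to compound 2 and its gap to compound 1 both lie within the scatter, so no order among these three is asserted.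

Compound 4 `Nc1nc(C(F)(F)F)cc2c1[nH]c(=O)n2Cc1ccc(NCCO)nc1` is the next member to be run. Relative to compound 3 the change is (2-hydroxyethyl)amino in place of methyl(2-(piperidin-1-yl)ethyl)amino on an aromatic carbon.

Measured steps that bear on this: a 1.9-fold higher number from compound 1 to compound 3 (0.28 log units; within the scatter) showed nothing beyond the scatter for the methyl on that nitrogen, and a 1.2-fold lower number from compound 2 to compound 3 (0.08 log units; within the scatter) likewise stayed within it. Only a 2.3-fold higher number from compound 1 to compound 2 (0.36 log units; beyond the scatter) went beyond the scatter, a modest shift. Compound 4 keeps, as compound 1 does, a hydrogen on the amino nitrogen, and compound 1 gives 13 mL.min-1.g-1. On that basis the step of a 2.5-fold lower number from compound 3 to compound 4 (0.40 log units; beyond the scatter) is expected to run toward a lower number, modest at most. Compound 4 is therefore estimated at 10 mL.min-1.g-1, with a range from 5 mL.min-1.g-1 to 20 mL.min-1.g-1.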

Compound 4, intrinsic clearance in microsomes: < 8 mL.min-1.g-1
Compound 4 ended at the assay's limit; the forecaster's own chance of this, stated with the estimate: 10%; at least 1.2-fold (0.09 log units) between middle value and limit.
By their numbers in this assay, from the lowest: compounds 1, 3 and 2 (each within the scatter of the next, the first and the last beyond it). At a limit, below all of these: compound 4.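

Compound 4 reads at a limit of this assay, not a number: the limit of < 8 mL.min-1.g-1 in this assay, at which 1 of the 4 values shown sits. Going by these compounds alone, on the aromatic carbon next to the ring nitrogen, (2-hydroxyethyl)amino gives steps beyond the scatter against both larger groups, an at least 3.1-fold lower number from compound 3 to compound 4 (0.49 log units; beyond the scatter) and an at least 3.7-fold lower number from compound 2 to compound 4 (0.57 log units; beyond the scatter), whereas among the earlier compounds only the step from compound 1 to compound 2 went beyond it. Hydroxy in place of piperidin-1-yl on the chain gives an at least 1.6-fold lower number from compound 1 to compound 4 (0.21 log units; that floor lies within the scatter), whose floor lies within the scatter, so this change is not yet separated from the scatter.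

The compounds shown do not separate the loss of the piperidin-1-yl ring from the entry of the hydroxy. As far as these compounds go, how a methoxy on the same chain, a plain ethylamino or a longer chain ending in hydroxy would read stays open.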